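The source may report more compounds than this note shows. Statements on the series, on what has been measured and on what is new or still open speak of the compounds shown alone.

Compound 1 `COc1ccccc1C1C(C#N)=C(N)N(c2ccc(S(N)(=O)=O)cc2)C2=C1C(=O)CCC2` sits lowest of the two numbers measured: in a functional assay on Ehrlich cells (Mus musculus) for antiproliferative activity, read by trypan blue exclusion, with a stated time of 2 h, tested at 10 ug/mL (a lower number here means a weaker effect, a higher number a stronger effect of the compound at the concentration tested), compound 1 gives 0%, while compound 2 `COc1ccc(C2C(C#N)=C(N)N(c3ccc(S(N)(=O)=O)cc3)C3=C2C(=O)CCC3)cc1` gives 30%. Among the compounds with values here, the one step known, a number 30 percentage points higher from compound 1 to compound 2 (beyond the scatter), came with 4-methoxyphenyl in place of 2-methoxyphenyl on a saturated ring carbon. Compound 3 `N#CC1=C(N)N(c2ccc(S(N)(=O)=O)cc2)C2=C(C(=O)CCC2)C1c1c(O)ccc2ccccc12` differs from compound 1 by 2-hydroxynaphthalen-1-yl in place of 2-methoxyphenyl on a saturated ring carbon. Within the data shown here, no measured step covers this replacement directly; the step from compound 1 to compound 2 only shows that changing this group can move the read-out beyond the scatter. On that basis a modest rise is expected, a number 20 percentage points higher from compound 1 to compound 3 (beyond the scatter). Compound 3 is estimated at 20%, within a range of 0% to 50%.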

Compound 3, a percentage reported as activity, at one concentration (the size of the read-out at that concentration, not a potency): 0%
Compound 3: the middle estimate sits 20 percentage points above what was measured; measured number inside the range.
By their numbers in this assay, from the lowest: compounds 1 and 3 (each within the scatter of the next); then compound 2.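

In this assay the change to 2-hydroxynaphthalen-1-yl on this saturated ring carbon gives no change at the digits printed from compound 1 to compound 3 (within the scatter) but a number 30 percentage points lower from compound 2 to compound 3 (beyond the scatter) when set against 4-methoxyphenyl. The read-out at this carbon therefore does not rise with every replacement of 2-methoxyphenyl: compound 3 stays within the scatter of compound 1, and only compound 2 stands apart. Nothing measured here explains the result.

Still open, going by these compounds, is how the added ring and the hydroxyl each count, which a naphthalen-1-yl or 2-hydroxyphenyl group would separate. A 4-aminophenyl group would test what the 4-methoxyphenyl result depends on.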